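The source may hold more compounds than are shown below. What is called first, only, known or untested is meant among the compounds shown, and "the series" means these compounds.

Among the measured compounds shown here, compound 2 `O=C(O)c1ccc(S(=O)(=O)N2CCC(NS(=O)(=O)c3cc(S(=O)(=O)c4ccccc4)ccc3C(F)(F)F)CC2)cc1` gives the lower of the two numbers so far in an assay on isolated protein for displacement of a labelled ligand from secreted frizzled-related protein 1 (Homo sapiens), read by fluorescence polarization, with a stated time of 30 min (a higher number here means a weaker inhibitor, a lower number a stronger inhibitor), at 20 nM; compound 1 `CN(C)c1ccc(C(=O)N2CCC(NS(=O)(=O)c3cc(S(=O)(=O)c4ccccc4)ccc3C(F)(F)F)CC2)cn1` gives 40 nM, and the step of a 2.0-fold lower number from compound 1 to compound 2 (0.30 log units; within the scatter) lies within the scatter. Compound 3 `N#Cc1cccc(S(=O)(=O)N2CCC(NS(=O)(=O)c3cc(S(=O)(=O)c4ccccc4)ccc3C(F)(F)F)CC2)c1` differs from compound 2 by 3-cyanophenyl in place of 4-carboxyphenyl on a sulfonyl sulfur. For the measured compounds named here, the one measured step, from compound 1 to compound 2, replaced the whole group on the ring amine nitrogen and stayed within the scatter; no measured step alters only the phenyl on the sulfonyl sulfur. Relative to compound 2, compound 3 is expected to show a step of a 1.5-fold higher number from compound 2 to compound 3 (0.18 log units; within the scatter), within the scatter. The estimate for compound 3 in this assay is 30 nM, ranging from 10 nM to 100 nM.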

Compound 3, half-maximal inhibitory concentration: 90 nM
The estimate for compound 3 lay 3.0-fold (0.48 log units) below the measured number; the range from low to high includes it.
By their numbers in this assay, from the lowest: compounds 2 and 1 (each within the scatter of the next); then compound 3.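

In this assay, among the compounds shown here, the change to 3-cyanophenyl in place of 4-carboxyphenyl on a sulfonyl sulfur gives a 4.5-fold higher number from compound 2 to compound 3 (0.65 log units; beyond the scatter) and is the first step beyond the scatter, so the number responds to the group on this sulfur. The (3-cyanophenyl)sulfonyl group also separates from (6-(dimethylamino)pyridin-3-yl)carbonyl on the ring nitrogen, with a 2.3-fold higher number from compound 1 to compound 3 (0.35 log units; beyond the scatter) as a modest step, which (4-carboxyphenyl)sulfonyl did not do.

Open, going by these compounds, is whether the step follows the carboxylic acid leaving or the nitrile entering, and how an amine on that phenyl would read. Nothing available bears on the cause of these steps.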